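The source may hold more compounds than are shown below. What is called first, only, known or untested is meant among the compounds shown, and "the series" means these compounds.

Measured so far in a toxicity assay on HepG2 2.2.15 cells (Homo sapiens) for cytotoxicity, read by CellTiter-Glo; a lower number here means that less compound is tolerated, a higher number that more compound is tolerated:

compound 1 `O=C1NC(c2ccccc2)CN1c1cnn2c1CN(C(=O)Nc1cc(F)c(F)c(F)c1)C(C1CC1)C2` gives 38500 nM
compound 2 `O=C(Nc1cc(F)c(F)c(F)c1)N1Cc2c(-c3ccc(F)cc3F)cnn2CC1C1CC1` gives 32100 nM
compound 3 `O=C1CC(c2ccccn2)CN1c1cnn2c1CN(C(=O)Nc1cc(F)c(F)c(F)c1)C(C1CC1)C2` gives 96200 nM

Compound 3 holds the highest number of the three, so it is the compound of which most is tolerated: the step of a 2.5-fold higher number from compound 1 to compound 3 (0.40 log units; beyond the scatter) and the step of a 3.0-fold higher number from compound 2 to compound 3 (0.48 log units; beyond the scatter) both lie beyond the scatter, while a 1.2-fold lower number from compound 1 to compound 2 (0.08 log units; within the scatter) stays within it.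

Compound 4 `O=C1CC(C(F)(F)F)CN1c1cnn2c1CN(C(=O)Nc1cc(F)c(F)c(F)c1)C(C1CC1)C2` differs from compound 3 in one place: trifluoromethyl in place of pyridin-2-yl on a saturated ring carbon.

None of the three measured steps changes a group on the saturated ring carbon; the steps from compound 1 and compound 2 to compound 3 exchange the whole substituent on the aromatic carbon, so they bear on the change to compound 4 only loosely. Those two steps were modest and both ran toward a higher number. With nothing pointing the other way, compound 4 is expected to stay near compound 3, with the step of a 1.3-fold lower number from compound 3 to compound 4 (0.11 log units; within the scatter) expected to fall within or close to the scatter. The estimate for compound 4 in this assay is 75000 nM, with a range from 30000 nM to 160000 nM.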

Compound 4, half-maximal cytotoxic concentration: 115000 nM
For compound 4 the middle estimate is 1.5-fold (0.19 log units) below the measured one; the measured number falls inside the stated range.
By their numbers in this assay, from the lowest: compounds 2 and 1 (each within the scatter of the next); then compounds 3 and 4 (each within the scatter of the next).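

Notes on the saturated ring carbon: in this assay, the step of a 1.2-fold higher number from compound 3 to compound 4 (0.08 log units; within the scatter) shows that this position accepts trifluoromethyl as well as pyridin-2-yl with no separation between the two, so an aromatic ring at this carbon is not needed for compound 4 to reach the level of compound 3. The 2-oxo-4-(trifluoromethyl)pyrrolidin-1-yl group also stands clear of the two other substituents on the aromatic carbon, with a 3.6-fold higher number from compound 2 to compound 4 (0.55 log units; beyond the scatter) and a 3.0-fold higher number from compound 1 to compound 4 (0.48 log units; beyond the scatter), as the pyridin-2-yl analogue did. Nothing on hand explains why these two groups give matching numbers.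

Open, going by these compounds, is whether a primary amine, a carboxylic acid or a longer alkyl chain on the same carbon would stay at this level. Also open, on these data alone, is whether a hydrogen alone there would do so.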